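Piperazine-sulfonyl thiazole hydroxamates: fluoro substitution on the phenyl

This account rests on a few compounds, and the source may have more. Where it says the series, first, only, none or still open, it means among the compounds named here.

Measured so far in a functional assay on MCF7 cells (Homo sapiens) for antiproliferative activity; on this read-out lower numbers stand for stronger inhibition of growth and higher numbers for weaker inhibition of growth:
- compound 1 `O=C(NO)c1cnc(N2CCN(S(=O)(=O)c3ccc(F)cc3)CC2)s1`: 3500 nM
- compound 2 `O=C(/C=C/c1cnc(N2CCN(S(=O)(=O)c3ccc(OC(F)(F)F)cc3)CC2)s1)NO`: 6000 nM
- compound 3 `O=C(/C=C/c1cnc(N2CCN(S(=O)(=O)c3ccccc3)CC2)s1)NO`: 3000 nM

Compound 3 gives the lowest number of the three in this assay, but its gaps to compound 1 and to compound 2 both lie within the scatter, so the three compounds cannot be ranked against each other.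

Compound 4 `O=C(/C=C/c1cnc(N2CCN(S(=O)(=O)c3ccc(F)cc3)CC2)s1)NO` differs from compound 3 by fluoro in place of hydrogen on an aromatic carbon. Within the data shown here, the one measured step that touches the same position is a 2.0-fold lower number from compound 2 to compound 3 (0.30 log units; within the scatter), which removed a larger group from that position and changed the number by no more than the scatter. Compound 1, which carries the same fluorophenyl but a different link to the hydroxamate, gives 3500 nM in this assay, again close to compound 3. Among the measured compounds shown here, no measured step at this position moves the number beyond the scatter.

A step from compound 3 to compound 4 of no change at the digits printed from compound 3 to compound 4 (within the scatter) is therefore expected, that is none beyond the scatter. For compound 4 the estimate is 3000 nM, with a range from 1500 nM to 6500 nM.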

Compound 4, concentration for 50% growth inhibition: 2500 nM
The estimate for compound 4 lay 1.2-fold (0.08 log units) above the measured number; low and high end bracket the measured number.
By their numbers in this assay, from the lowest: compounds 4, 3, 1 and 2 (each within the scatter of the next, the first and the last beyond it).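

In this assay, the phenyl to 4-fluorophenyl change on the aromatic carbon para to a large group gives a 1.2-fold lower number from compound 3 to compound 4 (0.08 log units; within the scatter), so fluoro and hydrogen cannot be told apart at this position. Among these compounds, the first step at this position to pass the scatter is a 2.4-fold lower number from compound 2 to compound 4 (0.38 log units; beyond the scatter), a modest step for fluoro in place of trifluoromethoxy, whereas hydrogen in place of trifluoromethoxy gave a 2.0-fold lower number from compound 2 to compound 3 (0.30 log units; within the scatter). With the 4-fluorophenyl held constant, 2-(hydroxycarbamoyl)ethenyl in place of hydroxycarbamoyl gives a 1.4-fold lower number from compound 1 to compound 4 (0.15 log units; within the scatter), so these two links cannot be told apart with this substituent.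

On these data alone, whether an amine or a carboxylic acid at this position, or a longer chain in place of the 2-(hydroxycarbamoyl)ethenyl link, would move the number further remains open. No supporting data explain the modest step from trifluoromethoxy to fluoro.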